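Furan-3-yl replacing the ethylpyrazole: clearance notes

The source may hold more compounds than are shown below. What is called first, only, known or untested is meant among the compounds shown, and "the series" means these compounds.

In an ADME assay (liver) for metabolic stability, with Liver microsome (Rattus norvegicus) as the target, using microsomes and NADPH, with a stated time of 30 min, tested at 1 uM (on this read-out higher numbers stand for fast clearance and lower numbers for slow clearance), compound 1 `Nc1ccc(S(=O)(=O)N2CCN(c3ncc(C(O)(C(F)(F)F)C(F)(F)F)cc3C#CCO)CC2)cn1` gives 65 mL.min-1.g-1 and compound 2 `CC(C)(O)C#Cc1cc(C(O)(C(F)(F)F)C(F)(F)F)cnc1N1CCN(S(=O)(=O)c2ccc(N)nc2)CC1` gives 16 mL.min-1.g-1 while compound 3 `CCn1cc(-c2cc(C(O)(C(F)(F)F)C(F)(F)F)cnc2N2CCN(S(=O)(=O)c3ccc(N)nc3)CC2)cn1` stands highest of the three at 194 mL.min-1.g-1 on these numbers. The change to compound 4 `Nc1ccc(S(=O)(=O)N2CCN(c3ncc(C(O)(C(F)(F)F)C(F)(F)F)cc3-c3ccoc3)CC2)cn1` is furan-3-yl in place of 1-ethyl-1H-pyrazol-4-yl on an aromatic carbon, counted as furan-3-yl in place of 1-ethyl-1H-pyrazol-4-yl on an aromatic carbon at that place. Changes on this carbon gave a 3.0-fold higher number from compound 1 to compound 3 (0.47 log units; beyond the scatter) (modest) and a 12-fold higher number from compound 2 to compound 3 (1.08 log units; beyond the scatter) (large) in the measured set. Among the measured compounds shown here, both steps start from a chain with a triple bond, and no measured step swaps one five-membered aromatic ring for another, so they fix no size here. The estimated step is a 1.3-fold lower number from compound 3 to compound 4 (0.11 log units; within the scatter) and is expected to stay within the scatter of this assay measurements. For compound 4 the estimate is 150 mL.min-1.g-1 with an expected range from 70 mL.min-1.g-1 to 320 mL.min-1.g-1 in this series.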

Compound 4, intrinsic clearance in microsomes: 57 mL.min-1.g-1
Compound 4: the middle estimate sits 2.6-fold (0.42 log units) above what was measured; measured number below the stated range.
By their numbers in this assay, from the lowest: compound 2; then compounds 4 and 1 (each within the scatter of the next); then compound 3.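

In this assay this position now has a step between two five-membered aromatic rings (a 3.4-fold lower number from compound 3 to compound 4 (0.53 log units; beyond the scatter)), so that exchange alone moves clearance beyond the scatter. Furan-3-yl reads level with the 3-hydroxyprop-1-yn-1-yl chain (a 1.1-fold lower number from compound 1 to compound 4 (0.06 log units; within the scatter)) but not with the 3-hydroxy-3-methylbut-1-yn-1-yl chain (a 3.6-fold higher number from compound 2 to compound 4 (0.55 log units; beyond the scatter)), so the aromatic ring does not always give the higher number at this carbon. Open, going by these compounds, is whether the gap between the two rings follows the ethyl group or the ring itself, which an unsubstituted pyrazole would separate, and what an amine such as morpholine would give on this aromatic carbon. No evidence bearing on these steps is at hand.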